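This account rests on a few compounds, and the source may have more. Where it says the series, first, only, none or still open, it means among the compounds named here.

Compound 3 `Cc1nc(-c2ccc(C(F)(F)F)cc2)sc1CNc1ccc([C@H]2C[C@@H]2C(N)=O)cc1` stands lowest of the three measured compounds in a functional assay on CHO cells for agonist activity at Free fatty acid receptor 1 (Homo sapiens) (a higher number here means that more compound is needed for the effect, a lower number that less compound is needed), where compound 3 gives 4.47 nM. Compound 2 `Cc1nc(-c2ccc(C(F)(F)F)cc2)sc1CNc1ccc(/C=C/C(=O)O)cc1` gives 36.3 nM and compound 1 `Cc1nc(-c2ccc(C(F)(F)F)cc2)sc1CNc1ccc(CCC(=O)O)cc1` gives 67.6 nM. The measured steps, a 15-fold lower number from compound 1 to compound 3 (1.18 log units; beyond the scatter) and an 8.1-fold lower number from compound 2 to compound 3 (0.91 log units; beyond the scatter), both swap the whole group on the aromatic carbon, while a 1.9-fold lower number from compound 1 to compound 2 (0.27 log units; within the scatter) stays within the scatter. Compound 4 `Cc1nc(-c2ccc(C(F)(F)F)cc2)sc1CNc1ccc([C@H]2C[C@@H]2C(=O)NC2CCNC2)cc1` changes something else: pyrrolidin-3-yl in place of hydrogen on an amide-type nitrogen. Within the data shown here, no measured step alters the amide nitrogen, so none bears directly on this change; the amide itself is kept. The expectation for compound 4 is therefore no step beyond the scatter, with a 1.3-fold higher number from compound 3 to compound 4 (0.13 log units; within the scatter) as the expected shift. Compound 4 is estimated at 6 nM, between 2 nM and 20 nM.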

Compound 4, half-maximal effective concentration: 204 nM
Beside the measured number, compound 4's estimate is 34-fold (1.53 log units) below it; the whole stated range lies below it.
By their numbers in this assay, from the lowest: compound 3; then compounds 2 and 1 (each within the scatter of the next); then compound 4.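

The amide nitrogen of compound 3 does not tolerate every substituent: pyrrolidin-3-yl in place of the amide hydrogen sharply raises the number (a 46-fold higher number from compound 3 to compound 4 (1.66 log units; beyond the scatter)). The advantage of 2-carbamoylcyclopropyl over the 2-carboxyethenyl and 2-carboxyethyl groups is also reversed (a 5.6-fold higher number from compound 2 to compound 4 (0.75 log units; beyond the scatter); a 3.0-fold higher number from compound 1 to compound 4 (0.48 log units; beyond the scatter)). Nothing available explains this loss.

Going by these compounds, whether any group on this nitrogen has the same effect remains open, since a methyl or a cyclopentyl group could behave differently. So does the effect of a carboxylic acid on the cyclopropyl ring in place of the amide.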